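Phenoxy in place of pyrrolidin-1-yl: what to expect

The compounds below may be only part of what the source reports. "The series", "measured", "known", "first", "only" and "open" are said of these compounds alone.

In a functional assay on Caco-2 cells (Homo sapiens) for antiproliferative activity, with a stated time of 48 h (on this read-out higher numbers stand for weaker inhibition and lower numbers for stronger inhibition), compound 3 `FC(F)(F)c1cccc(-c2ccc(N3CCCC3)nn2)c1` gives 50000 nM, and compound 2 `CN1CCN(c2ccc(-c3cccc(C(F)(F)F)c3)nn2)CC1` gives 50000 nM. These two compounds stand level, and compound 3 has no neighbour with a readable difference. For compound 1 `CCN(CC)c1ccc(-c2cccc(C(F)(F)F)c2)nn1` the assay reports only a limit, > 25000 nM. That leaves a step that the limit leaves unreadable from compound 1 to compound 2 and a step that the limit leaves unreadable from compound 1 to compound 3, so neither of these steps can guide a prediction.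

The next compound, compound 4 `FC(F)(F)c1cccc(-c2ccc(Oc3ccccc3)nn2)c1`, carries phenoxy in place of pyrrolidin-1-yl on an aromatic carbon. Going by the values given here, the only readable exchange at this place is no change at the digits printed from compound 2 to compound 3 (within the scatter). That is a single step, and it did not bring in an aromatic ring, so it is a loose guide. Resting on that step, the expectation in this assay is no change beyond the scatter, with neither direction favoured, and the estimated result is a 1.3-fold lower number from compound 3 to compound 4 (0.10 log units; within the scatter). Compound 4 is estimated at 40000 nM, with an expected range from 15000 nM to 100000 nM.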

Compound 4, half-maximal inhibitory concentration: > 25000 nM
Compound 4: a limit, no number; the forecaster's own chance of this, stated with the estimate: 35%; the middle value does not contradict the limit.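

In this assay compound 4 gives > 25000 nM, a limit and not a number, so no step from compound 1, compound 2 or compound 3 to compound 4 can be read: the limit of > 25000 nM in this assay, at which 2 of the 4 values shown sit.

The compounds shown leave open whether phenoxy in place of pyrrolidin-1-yl changes the inhibition at all, and in which direction.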